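Phenyl for methyl on the saturated ring of compound 1

This account rests on a few compounds, and the source may have more. Where it says the series, first, only, none or still open, it means among the compounds named here.

Compound 1 `CC1CN(S(=O)(=O)C[C@]23CC[C@H](CC2=O)C3(C)C)CCN1c1ccc(C(F)(F)F)cn1` was tested in a functional assay on CHO-K1 cells for antagonist activity at C-X-C chemokine receptor type 3 (Homo sapiens), read by FLIPR and calcium flux (on this read-out higher numbers stand for weaker inhibition and lower numbers for stronger inhibition), where compound 1 gives 316 nM. Compound 2 `C[C@@H]1CN(S(=O)(=O)C[C@]23CC[C@H](CC2=O)C3(C)C)CCN1c1ccc(C(F)(F)F)cn1` is the same molecule with one stereocentre drawn as a fixed configuration; in this assay compound 2 gives 501 nM. The step of a 1.6-fold higher number from compound 1 to compound 2 (0.20 log units; within the scatter) shows that fixing that configuration changes little, and the only fact that might account for it is the fact that one of compounds 1 and 2 is drawn with a defined configuration and the other without, at the place where they differ. Among the two measured compounds, compound 1 carries the lower number, but its gap to compound 2 is inside the scatter, so no order can be read from it.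

Compound 3 `CC1(C)[C@@H]2CC[C@@]1(CS(=O)(=O)N1CCN(c3ccc(C(F)(F)F)cn3)C(c3ccccc3)C1)C(=O)C2` differs from compound 1 by the change (phenyl in place of methyl on a saturated ring carbon), that is, phenyl in place of methyl on a saturated ring carbon. Among the measured compounds shown here, no measured step covers a swap of this kind; the only measured step, from compound 1 to compound 2, concerns configuration rather than the size of the group, so it gives no guide to direction. The expected step is therefore a 1.3-fold higher number from compound 1 to compound 3 (0.10 log units; within the scatter), with wide uncertainty. Compound 3 is estimated at 400 nM, within a range from 80 nM to 3000 nM.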

Compound 3, half-maximal inhibitory concentration: > 31600 nM
Compound 3 was reported as a limit (the forecaster's own chance of this, stated with the estimate: 15%); middle value at least 79-fold (1.89 log units) away from the limit.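

Compound 1 and compound 2 differ only in how this ring carbon is drawn, so they showed nothing about which group it can carry. In this assay putting phenyl in place of methyl on this saturated ring carbon, two ring bonds from the ring nitrogen, gives an at least 100-fold higher number from compound 1 to compound 3 (2.00 log units; beyond the scatter) and so shows that the group at this place can decide whether any inhibition is seen in the tested range. Compound 3 gives > 31600 nM and this is a limit of the assay and not a number, so the step is a minimum, and the reading of it rests on this: the limit of > 31600 nM in this assay, at which 1 of the 3 values shown sits.

The compounds shown leave open how the numbers run between methyl and phenyl, for instance with an ethyl group, a cyclopropyl ring or a hydroxymethyl group on this carbon. They also leave open whether a polar group such as an amine or a carboxylic acid would fare differently here, and whether either configuration of compound 3 at this carbon would differ from the form drawn without one.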